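Toxicity notes on three measured amides and a fourth to come

This account rests on a few compounds, and the source may have more. Where it says the series, first, only, none or still open, it means among the compounds named here.

Measured so far:
compound 1 `COc1ccccc1-c1cnc(NC(=O)c2ccc(F)cc2)n1C` gives > 100000 nM in a toxicity assay on THP-1 cells (Homo sapiens) for inhibition; on this read-out lower numbers stand for higher toxicity in this test and higher numbers for lower toxicity in this test
compound 2 `COc1ccc(-c2cnc(NC(=O)c3cccnc3)n2C)cc1` gives > 100000 nM in this assay
compound 3 `COc1ccc(-c2ccnc(NC(=O)c3ccc(F)cc3)c2)cc1` gives > 100000 nM in this assay

Every value here is a limit of the test and not a number. Compound 2 stands at that limit in this assay, and the two other values are limits as well, so no ranking among the three can be read from these numbers (the limit of > 100000 nM in this assay, at which 3 of the 3 values shown sit). Among the measured compounds shown here, no pair of measured compounds differs in a single place, so no measured step is available.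

Compound 4 `COc1ccc(-c2cnc(NC(=O)c3ccccc3OC)n2C)cc1` is still to be measured in this assay. It differs from compound 2 in one place: 2-methoxyphenyl in place of pyridin-3-yl on a carbonyl carbon. With all three measured values sitting at the limit, there is nothing among them that would point to a change on this amide substituent, and compounds 1 and 3 carry other amide groups on differing cores while still reaching the limit.

The step of a number no higher from compound 2 to compound 4 (the limit leaves the size open) is therefore expected to be none beyond the scatter. For compound 4 the expected result in this assay is 100000 nM, with a range from 50000 nM to 200000 nM, most probably reported again only as a limit.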

Compound 4, half-maximal cytotoxic concentration: > 100000 nM
Compound 4 ended at the assay's limit; the forecaster's own chance of this, stated with the estimate: 85%; the middle value lies on the limit itself.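

Compound 4, like compound 2, sits at a limit of this assay and not at a number, so no step can be read from compound 2 to compound 4: the limit of > 100000 nM in this assay, at which 4 of the 4 values shown sit.

The compounds shown leave open whether any of these amide groups or cores gives a measurable cytotoxic concentration in this assay, and how they would rank.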